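The compounds below may be only part of what the source reports. "The series", "measured", "known", "first", "only" and "open" are said of these compounds alone.

Measured compounds:
compound 1 `N#Cc1ccc(-c2nc(C(c3ccc(F)cc3)c3ccc(F)cc3)sc2CC(=O)O)cc1` — 30%
compound 2 `O=C(O)Cc1sc(C(c2ccc(F)cc2)c2ccc(F)cc2)nc1-c1cc(F)cc(F)c1` — 80%
compound 3 `O=C(O)Cc1sc(C(c2ccc(F)cc2)c2ccc(F)cc2)nc1-c1ccoc1` — 80%

In an in vitro functional assay on HEK285-7 cells for antagonist activity at prostaglandin D2 receptor 2 (Homo sapiens), read by BRET and beta-arrestin recruitment (on this read-out lower numbers stand for smaller maximal responses and higher numbers for larger maximal responses), compound 3 stands level with compound 2 and, together with it, at the top of the three numbers. The step of no change at the digits printed from compound 2 to compound 3 (within the scatter) stays within the scatter, while a number 50 percentage points higher from compound 1 to compound 3 (beyond the scatter) lies well beyond it.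

Compound 4 `O=C(O)Cc1sc(C(c2ccc(F)cc2)c2ccc(F)cc2)nc1-c1ccnc(O)c1` has not yet been measured. It differs from compound 3 at the same aromatic carbon of the shared core where all three measured compounds differ: 2-hydroxypyridin-4-yl in place of furan-3-yl on an aromatic carbon.

All three measured steps bear on this change, since each swaps the group at that carbon. Two were large, a number 50 percentage points higher from compound 1 to compound 2 (beyond the scatter) and a number 50 percentage points higher from compound 1 to compound 3 (beyond the scatter), and one showed nothing, no change at the digits printed from compound 2 to compound 3 (within the scatter). Only compound 1, with 4-cyanophenyl, gave the low number; 3,5-difluorophenyl and furan-3-yl gave the high one. The entering 2-hydroxypyridin-4-yl, a six-membered ring carrying one hydrogen-bond donor, resembles neither, so a downward step of moderate size is expected, with wide uncertainty. For compound 4 a maximal response of 60% is expected, with a range from 30% to 90%. The step thus expected is a number 20 percentage points lower from compound 3 to compound 4 (beyond the scatter).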

Compound 4, largest response reached (reported as efficacy), in percent of the reference or control that the assay uses: 60%
Estimate against measurement, compound 4: no gap at the digits printed; low and high end bracket the measured number.
By their numbers in this assay, from the lowest: compound 1; then compound 4; then compounds 2 and 3 (each within the scatter of the next).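

At this aromatic carbon, 2-hydroxypyridin-4-yl takes a level of its own in this assay with a number 20 percentage points lower from compound 3 to compound 4 (beyond the scatter) and a number 20 percentage points lower from compound 2 to compound 4 (beyond the scatter) on one side and a number 30 percentage points higher from compound 1 to compound 4 (beyond the scatter) on the other. The earlier compounds shown here showed only a low and a high level here, so across these four groups the position now reads as graded and not as split in two. Nothing available gives a reason for this middle level.

On these data alone, a plain pyridin-4-yl and a 4-hydroxyphenyl at this carbon would help separate the part played by the ring nitrogen from that of the hydroxyl, and that question stays open. As far as these compounds go, how an amine in place of the hydroxyl, as in 2-aminopyridin-4-yl, would compare also stays open.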